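Ester chain length and serine protease 1 inhibition

This account rests on a few compounds, and the source may have more. Where it says the series, first, only, none or still open, it means among the compounds named here.

Measured compounds:
compound 1, `CCCCCCOC(=O)c1ccc(CN)cc1`: 300000000 nM
compound 2, `NCc1ccc(C(=O)OCCc2ccccc2)cc1`: 600000000 nM
compound 3, `CCCCCOC(=O)c1ccc(CN)cc1`: 700000000 nM

All three numbers come from an assay on isolated protein for inhibition of serine protease 1 (Homo sapiens); on this read-out lower numbers stand for stronger inhibition and higher numbers for weaker inhibition. Compound 1 stands at the lowest number of the three; the step of a 2.0-fold higher number from compound 1 to compound 2 (0.30 log units; within the scatter) is within the scatter, whereas the step of a 2.3-fold higher number from compound 1 to compound 3 (0.37 log units; beyond the scatter) is beyond it. The step of a 1.2-fold higher number from compound 2 to compound 3 (0.07 log units; within the scatter) is within the scatter, so compound 2 and compound 3 are not separated.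

Compound 4, `CCCOC(=O)c1ccc(CN)cc1`, is not yet measured in this assay. Against compound 1 the change is hydrogen in place of propyl on a saturated chain carbon, three bonds along the chain from an oxygen next to a carbonyl group. Of the measured steps, only the shortening from compound 1 to compound 3 bears directly on this change; it removed one chain carbon and gave a modest rise in the number. For the measured compounds named here, compound 4 removes three chain carbons from compound 1, so a larger rise in the number than the one seen from compound 1 to compound 3 is expected, though no measured step covers this span and the expectation is loose. For compound 4 the estimate in this assay is 2000000000 nM with a range from 600000000 nM to 7000000000 nM. This estimate means a step of a 6.7-fold higher number from compound 1 to compound 4 (0.82 log units; beyond the scatter), expected to lie beyond the scatter.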

Compound 4, inhibition constant: 500000000 nM
Estimate against measurement, compound 4: 4.0-fold (0.60 log units) above; measured number below the stated range.
By their numbers in this assay, from the lowest: compounds 1, 4, 2 and 3 (each within the scatter of the next, the first and the last beyond it).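

In this assay, hydrogen in place of propyl on a saturated chain carbon, three bonds along the chain from an oxygen next to a carbonyl group, stays within the scatter, with a 1.7-fold higher number from compound 1 to compound 4 (0.22 log units; within the scatter), so this change does not separate the two compounds. The steps of a 1.4-fold lower number from compound 3 to compound 4 (0.15 log units; within the scatter) and a 1.2-fold lower number from compound 2 to compound 4 (0.08 log units; within the scatter) also stay within the scatter, so a number that climbs with each chain carbon removed does not hold across these compounds: compound 4 goes against it, and a 2.3-fold higher number from compound 1 to compound 3 (0.37 log units; beyond the scatter) remains a lone step just beyond the scatter. Nothing available explains why removing the propyl leaves so little mark on the number.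

Still open, on these data alone, is whether an ethyl or methyl at this end of the chain, or a longer chain such as octyl, would move the number beyond the scatter in this assay. Also open, as far as these compounds go, is how a terminal hydroxyl or amine on the chain, or an amide or carboxylic acid in place of the ester, would compare with compound 1.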